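The compounds below may be only part of what the source reports. "The series", "measured", "known", "first", "only" and "open" are said of these compounds alone.

Measured in an assay for binding affinity to Neuronal acetylcholine receptor; alpha4/beta2 (Rattus norvegicus) (on this read-out lower numbers stand for stronger inhibition and higher numbers for weaker inhibition), so far:

compound 1 `Oc1ccc2cc3c(cc2n1)C1CNCC3C1`, giving 8.5 nM
compound 2 `c1ccc(-c2nc3cc4c(cc3[nH]2)C2CNCC4C2)cc1`, giving 14 nM
compound 3 `CC(C)c1nc2cc3c(cc2o1)C1CNCC3C1`, giving 7.6 nM

Compound 1 has the second highest number of the three, with compound 3 nearest and compound 2 furthest; both gaps lie within the scatter, so no order among the three can be read from these values.

Compound 4 `c1cnc2cc3c(cc2c1)C1CNCC3C1` is not yet measured. It differs from compound 1 in one place: hydrogen in place of hydroxy on an aromatic carbon — hydrogen in place of hydroxy on an aromatic carbon. Among the measured compounds shown here, no measured pair shows this step, and the three values together speak for a core that tolerates varied substitution. A small to moderate move toward weaker binding is expected, a 2.4-fold higher number from compound 1 to compound 4 (0.37 log units; beyond the scatter), partly beyond the scatter. Compound 4 is thus estimated at 20 nM, with a range of 6 nM to 70 nM.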

Compound 4, inhibition constant: 1.6 nM
Estimate against measurement, compound 4: 13-fold (1.10 log units) above; measured number below the stated range.
By their numbers in this assay, from the lowest: compound 4; then compounds 3, 1 and 2 (each within the scatter of the next).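

In this assay, hydrogen in place of hydroxy on an aromatic carbon next to the ring nitrogen brings a 5.3-fold lower number from compound 1 to compound 4 (0.73 log units; beyond the scatter) and gives the series its first step at a single place. Hydroxy is therefore not needed at this position for strong binding, and losing it improves the number. Nothing measured here gives a reason for this step.

On these data alone, how methoxy, chlorine or an amine on this same carbon would compare with hydrogen and hydroxy remains open. Also open, as far as these compounds go, is whether the same change would have a similar effect on other cores.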